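A few compounds are considered here, and "the series" means these few. Any claim that something is new, unique, unknown or untested is made for them only; others in the source may bear on it.

Three compounds share one core and differ only in the group sitting on an amine nitrogen in a ring. Compound 1 `COc1ccc(C2CC(c3ccc(NC(=O)c4cc(Cl)ccc4OC)cc3)=NN2C)cc1` carries a methyl there, and in a functional assay on the whole organism (strain albino) with Rattus norvegicus as the target, read by paw edema, with stated times of 1 h and 4 h, at a dose of 50 mg/kg by the oral route (a higher number here means a stronger effect of the compound at the dose given, a lower number a weaker effect), compound 1 gives 93.2%. Compound 2 `COc1ccc(C2CC(c3ccc(NC(=O)c4cc(Cl)ccc4OC)cc3)=NN2c2ccccc2)cc1` carries a phenyl in that place, and in this assay compound 2 gives 98%. Compound 3 `COc1ccc(C2CC(c3ccc(NC(=O)c4cc(Cl)ccc4OC)cc3)=NN2)cc1` carries only a hydrogen on that nitrogen, and in this assay compound 3 gives 89%, the smallest of the three numbers shown, although both gaps to it lie within the scatter: a number 4.2 percentage points lower from compound 1 to compound 3 (within the scatter) and a number 9 percentage points lower from compound 2 to compound 3 (within the scatter).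

Compound 4 `COc1ccc(C2CC(c3ccc(NC(=O)c4cc(Cl)ccc4OC)cc3)=NN2C(C)=O)cc1` has not yet been measured. The change from compound 3 is acetyl in place of hydrogen on an amine nitrogen in a ring. Both earlier steps bear on this one, since each of them also exchanged the group on this same nitrogen, and neither moved the number beyond the scatter, whether the group was methyl, phenyl or hydrogen. No step beyond the scatter is therefore expected in this assay; the expected step is a number 3 percentage points higher from compound 3 to compound 4 (within the scatter). Compound 4 is estimated to give 92%, with a range from 82% to 99%.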

Compound 4, a percentage reported as activity, at one dose (the size of the read-out at that dose, not a potency): 90.2%
Beside the measured number, compound 4's estimate is 1.8 percentage points above it; low and high end bracket the measured number.
By their numbers in this assay, from the lowest: compounds 3, 4, 1 and 2 (each within the scatter of the next).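

Acetyl is the first group on this nitrogen to bring a carbonyl, and in this assay the number stays level with the earlier compounds: a number 1.2 percentage points higher from compound 3 to compound 4 (within the scatter) and a number 3 percentage points lower from compound 1 to compound 4 (within the scatter) and a number 7.8 percentage points lower from compound 2 to compound 4 (within the scatter). Hydrogen, methyl, phenyl and now acetyl therefore all give numbers within the scatter of one another at this position, so the carbonyl adds no visible step to what the earlier compounds showed. No evidence at hand explains why the number holds so steady across these four groups.

Going by these compounds, it remains open whether a different kind of group on this nitrogen, such as a carboxylic acid or an amine at the end of a longer chain, would also leave the number level. A reading at one dose gives the size of the effect rather than a potency, so these four compounds could still separate at lower doses.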